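The source may hold more compounds than are shown below. What is called first, only, known or untested is meant among the compounds shown, and "the series" means these compounds.

Three compounds that share a core were examined in a functional assay on L1210 cells (Mus musculus), with a stated time of 12 days; a higher number here means a more potent compound, by a factor of ten per unit of this negative logarithm, a lower number a less potent compound. Compound 1, `CCCC1=C(N2CC2)C(=O)C(C(COC(N)=O)OC)=C(N2CC2)C1=O`, gives 5.07 in this assay. Compound 2, `CCC1=C(N2CC2)C(=O)C(C(COC(N)=O)OC)=C(N2CC2)C1=O`, gives 5.22. These two differ in a single place, (methyl in place of hydrogen on a saturated chain carbon, two bonds along the chain from a double-bonded ring carbon), and the resulting step, a number 0.15 log units lower from compound 2 to compound 1 (within the scatter), so the two values are best read as equal. Compound 3, `CC1=C(N2CC2)C(=O)C(C(C)COC(N)=O)=C(N2CC2)C1=O`, gives 5.71, the highest of the three values, standing beyond the scatter above both compound 2 and compound 1. How the core of compound 3 differs from the core of compound 2 is not broken down here.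

Compound 4, `CCC(COC(N)=O)C1=C(N2CC2)C(=O)C(C)=C(N2CC2)C1=O`, has not yet been measured. It differs from compound 3 by methyl in place of hydrogen on a saturated chain carbon, two bonds along the chain from a double-bonded ring carbon, at the same place as the change that leads from compound 2 to compound 1, so the two changes are the same. Because the earlier step of a number 0.15 log units lower from compound 2 to compound 1 (within the scatter) stayed within the scatter, the step of a number 0.16 log units lower from compound 3 to compound 4 (within the scatter) is expected to be of similarly small size, with compound 3 as the only available anchor. Compound 4 is therefore estimated at 5.55, within a range from 5.15 to 5.95.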

Compound 4, logarithm of the reciprocal of the active concentration, log(1/C): 5.66
Compound 4: the middle estimate sits 0.11 log units below what was measured; measured number inside the range.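

In this assay, putting methyl in place of hydrogen on a saturated chain carbon, two bonds along the chain from a double-bonded ring carbon, gives a number 0.05 log units lower from compound 3 to compound 4 (within the scatter), so compound 3 and compound 4 are best read as equal. Set beside the earlier case, the change behaves alike on both cores, leaving the value essentially where it was each time: the same change on two cores in this assay, a number 0.15 log units lower (within the scatter) from compound 2 to compound 1 and a number 0.05 log units lower (within the scatter) from compound 3 to compound 4, 0.10 log units apart, within the scatter of two such steps. This shows only that the small effect of this one change carried over between these two cores in this one assay; with both steps inside the scatter, it gives no measurable effect to transfer, and it does not show that the same would hold on any other core.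

The compounds shown leave open what a larger group at this place would do, such as a longer chain like butyl, a phenyl ring or an amine. They also leave open whether the equal values would persist in any other assay.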